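This account rests on a few compounds, and the source may have more. Where it says the series, first, only, none or still open, it means among the compounds named here.

Compound 1 `COc1ccc(-c2c(C)nc3c(N4CC[C@@H](NC(C)=O)C4)cc(C)nn23)cc1OC` and compound 2 `COc1cc(-c2c(C)nc3c(N4CC[C@@H](NC(C)=O)C4)cc(C)nn23)cc(OC)c1OC` share one core and are measured in an ADME assay on microsomes from liver (Homo sapiens) for metabolic stability, read by LC-MS, with NADPH named in the record, with a stated time of 60 min, tested at 1 uM, in the absence of a further agent; on this read-out lower numbers stand for a less stable compound and higher numbers for a more stable compound. In this assay compound 1 gives > 95%, which is a limit of the assay rather than a number. In this assay compound 2 gives > 95%, likewise a limit. Among the measured compounds shown here, the one step measured within the pair is a step that the two limits leave unreadable from compound 1 to compound 2, and it bears on the present question only by showing that both compounds sit at the limit of > 95% in this assay, at which 2 of the 2 values shown sit. Compound 3 `COc1ccc(-c2c(C)nc3c(N4CC[C@@H](NC(C)=O)C4)cc(C)nn23)cc1F` differs from compound 1 by fluoro in place of methoxy on an aromatic carbon. For the measured compounds named here, no measured step covers this kind of change, so the expectation rests on where compound 1 stands: at the limit, with no number to move from. Compound 3 is therefore expected to sit at the same limit, with a step of a number no higher from compound 1 to compound 3 (the limit leaves the size open) that is no step beyond the scatter. The estimate for compound 3 is 95%, within 85% to 99%.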

Compound 3, percent of the compound remaining: > 95%
Compound 3 was reported as a limit; the forecaster's own chance of this, stated with the estimate: 70%; the middle value lies on the limit itself.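

The step between compound 1 and compound 3 in this assay cannot be read, as each compound stands at a limit and not at a number: the limit of > 95% in this assay, at which 3 of the 3 values shown sit.

The compounds shown leave open whether fluoro in place of methoxy changes the percent of compound remaining at all.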